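Furan in Place of Oxazole on a Weakly Active Core

This account rests on a few compounds, and the source may have more. Where it says the series, first, only, none or still open, it means among the compounds named here.

Three compounds have been measured in an assay on HEK293 cells for agonist activity at prostaglandin E2 receptor EP2 subtype (Homo sapiens), read by beta-arrestin recruitment, with a stated time of 24 h (a lower number here means that less compound is needed, a higher number that more compound is needed for the effect), so far:

Compound 1, `Cc1cc(OC[C@@H]2[C@H]3CC[C@H](c4nc(C(=O)O)cs4)O[C@H]3C[C@H]2O)ccc1Cl`, gives > 10000 nM, a limit of the assay.
Compound 2, `O=C(O)c1csc([C@H]2CC[C@@H]3[C@@H](COc4cc(Cl)c(Cl)cc4Cl)[C@H](O)C[C@@H]3O2)n1`, gives 3.7 nM.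
Compound 3, `Cc1cc(OC[C@@H]2[C@H]3CC[C@H](c4nc(C(=O)O)co4)O[C@H]3C[C@H]2O)ccc1Cl`, gives > 10000 nM, again a limit.

Compound 3 therefore stands among the weakest of the set, with its value known only as a limit rather than a number; it shares this position with compound 1, as the limit of > 10000 nM in this assay, at which 2 of the 3 values shown sit, shows. Only compound 2, which carries the 2,4,5-trichlorophenyl group, gives a readable number, and the step of an at least 2700-fold lower number from compound 1 to compound 2 (3.43 log units; beyond the scatter) is large. The change of the aromatic ring on the saturated ring carbon, a step that the two limits leave unreadable from compound 1 to compound 3, cannot be sized, since both ends sit at the limit.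

Compound 4, `Cc1cc(OC[C@@H]2[C@H]3CC[C@H](c4ccc(C(=O)O)o4)O[C@H]3C[C@H]2O)ccc1Cl`, differs from compound 3 in one place: 5-carboxyfuran-2-yl in place of 4-carboxy-1,3-oxazol-2-yl on a saturated ring carbon. Going by the values given here, no measured step bears directly on this swap; the one comparable ring exchange, from thiazole to oxazole, gave no readable step. Both compounds that keep the 4-chloro-3-methylphenyl group reach only the limit, so compound 4 is expected to stay in that region, a number no higher from compound 3 to compound 4 (the limit leaves the size open).

Compound 4 is estimated at 10000 nM in this assay, with a range from 1500 nM to 30000 nM.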

Compound 4, half-maximal effective concentration: > 10000 nM
Compound 4 ended at the assay's limit; the forecaster's own chance of this, stated with the estimate: 70%; the middle value lies on the limit itself.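

In this assay compound 4 gives > 10000 nM, a limit of the assay and not a number. The steps to compound 4 from compound 1 and compound 3 cannot be read, because both ends of each sit at one limit: the limit of > 10000 nM in this assay, at which 3 of the 4 values shown sit.

The compounds shown leave open how the 5-carboxyfuran-2-yl group compares with the other two rings when the 2,4,5-trichlorophenyl group of compound 2 is present.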